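This account rests on a few compounds, and the source may have more. Where it says the series, first, only, none or still open, it means among the compounds named here.

Measured so far in an assay on HEK293 cells for activation of Kir3.1/Kir3.2 (Homo sapiens), read by thallium flux; a higher number here means a larger maximal response, a lower number a smaller maximal response:
compound 1 `Cc1cc(NC(=O)Cn2nnc(-c3ccccc3)n2)n(C2CCCCC2)n1` — 92%
compound 2 `Cc1cc(NC(=O)Cn2nnc(-c3ccccc3)n2)n(C2CCC(F)(F)CC2)n1` — 68%
compound 3 `Cc1cc(NC(=O)Cn2nnc(-c3ccccc3)n2)n(-c2ccccc2)n1` — 66%

Compound 1 holds the highest of the three numbers. Its nearest neighbour is compound 2, reached by a number 24 percentage points lower from compound 1 to compound 2 (beyond the scatter); the furthest is compound 3, reached by a number 26 percentage points lower from compound 1 to compound 3 (beyond the scatter). Between compound 2 and compound 3 lies a number 2 percentage points lower from compound 2 to compound 3 (within the scatter), so those two values are not separated. All three measured steps exchange the group on the aromatic nitrogen of the shared core, while the phenyl at the other end is kept throughout.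

Compound 4 `Cc1ccc(-c2nnn(CC(=O)Nc3cc(C)nn3C3CCCCC3)n2)cc1` differs from compound 1 at that other end: methyl in place of hydrogen on an aromatic carbon. For the measured compounds named here, no measured step touches this phenyl, so the measured steps give no direct guide; they show only that the series sits in a band from compound 3 up to compound 1. The change is a single carbon, and with nothing measured against it the expectation in this assay is a step no larger than the scatter, in either direction. Compound 4 is therefore expected near 88%, spanning 68% to 104%. This amounts to an estimated step of a number 4 percentage points lower from compound 1 to compound 4 (within the scatter), that is, no change expected beyond the scatter.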

Compound 4, largest response reached (Emax), in percent of the reference or control that the assay uses: 86%
Beside the measured number, compound 4's estimate is 2 percentage points above it; low and high end bracket the measured number.
By their numbers in this assay, from the lowest: compounds 3 and 2 (each within the scatter of the next); then compounds 4 and 1 (each within the scatter of the next).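

For the compounds shown here, the phenyl end of the shared core is varied here for the first time. In this assay, the change from phenyl to 4-methylphenyl gives a step within the scatter (a number 6 percentage points lower from compound 1 to compound 4 (within the scatter)), so a methyl on this aromatic carbon, para to a large group, leaves no separable change in maximal response. Going by these compounds alone, the two steps beyond the scatter both involve the group on the aromatic nitrogen, whereas this single methyl shows only that one small group is tolerated at this end, and no available evidence bears on this result.

Still open, from the compounds shown here alone, is whether a chlorine, a methoxy group, an amine or a carboxylic acid at this place would behave in the same way. Also open, going by these compounds, is whether the methyl gives the same outcome with 4,4-difluorocyclohexyl or phenyl on the aromatic nitrogen.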